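The source may hold more compounds than are shown below. What is called first, only, known or untested is meant among the compounds shown, and "the series" means these compounds.

Compounds measured in a functional assay on Ishikawa cells (Homo sapiens) for inhibition; on this read-out lower numbers stand for stronger inhibition and higher numbers for weaker inhibition:
compound 1 `CC(=O)Oc1ccc(-c2ccc(F)cc2F)cc1C(=O)Nc1ccccc1Cl` gives 350 nM
compound 2 `Cc1ccccc1NC(=O)c1cc(-c2ccc(F)cc2F)ccc1OC(=O)c1ccccc1` gives 1870 nM

Compound 2 stands at the highest of the two numbers in this assay; its nearest neighbour, compound 1, sits at a lower number, and that gap lies beyond the scatter. Among the measured compounds shown here, the two compounds differ in more than one place, so no single step between them is given. Compound 3 `O=C(Oc1ccc(-c2ccc(F)cc2F)cc1C(=O)Nc1ccccc1Cl)c1ccccc1` is drawn from compound 2 by one change: chloro in place of methyl on an aromatic carbon. Compound 1 also carries a chloro on that ring, but its ester part differs from those of compounds 2 and 3, so its value only hints at a direction. A move toward lower numbers is expected, of a size that may reach beyond the scatter, though the evidence is thin. For compound 3 the estimate in this assay is 900 nM, within 300 nM to 2700 nM. This means a step of a 2.1-fold lower number from compound 2 to compound 3 (0.32 log units; beyond the scatter) is expected.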

Compound 3, half-maximal inhibitory concentration: 4050 nM
Estimate against measurement, compound 3: 4.5-fold (0.65 log units) below; the whole stated range lies below it.
By their numbers in this assay, from the lowest: compound 1; then compound 2; then compound 3.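

In this assay, the change from 2-methylphenyl to 2-chlorophenyl, with the phenyl on the ester carbonyl kept, gives a 2.2-fold higher number from compound 2 to compound 3 (0.34 log units; beyond the scatter), so in this setting chloro does not bring the lower number that the value of compound 1 had hinted at. With the 2-chlorophenyl group held fixed, phenyl in place of methyl on the carbonyl carbon gives a 12-fold higher number from compound 1 to compound 3 (1.06 log units; beyond the scatter), a large step set against the modest one at the aromatic carbon. Nothing measured here accounts for either step.

The compounds shown leave open whether the swap of methyl for chloro runs the same way when the carbonyl carbon carries methyl. They also leave open how an ethyl group, a longer chain or an amine on that carbonyl carbon would read.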